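Amino-to-aminopyrrolidinyl step in the propanamide series

The compounds below may be only part of what the source reports. "The series", "measured", "known", "first", "only" and "open" are said of these compounds alone.

Within the data shown here, compound 3 `Nc1ccc2cc(NC(=O)CCc3ccc(C(F)(F)F)cc3)ccc2n1` gives 720 nM in a functional assay on HEK293 cells for activation of melanin-concentrating hormone receptor 1 (Rattus norvegicus), read by inositol phosphate accumulation (a higher number here means that more compound is needed for the effect, a lower number that less compound is needed), which puts it second highest of the three numbers so far. Its nearest neighbour is compound 1 `CN(c1ccc2cc(NC(=O)CCc3ccc(C(F)(F)F)cc3)ccc2n1)C1CCCCC1` at 1200 nM; the gap a 1.7-fold lower number from compound 1 to compound 3 (0.22 log units; within the scatter) stays within the scatter, so no order between the two is claimed. The furthest is compound 2 `CC(C)C(=O)NC1CCN(c2ccc3cc(NC(=O)CCc4ccc(C(F)(F)F)cc4)ccc3n2)C1` at 90 nM, with an 8.0-fold higher number from compound 2 to compound 3 (0.90 log units; beyond the scatter).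

Compound 4 `NC1CCN(c2ccc3cc(NC(=O)CCc4ccc(C(F)(F)F)cc4)ccc3n2)C1` differs from compound 3 by 3-aminopyrrolidin-1-yl in place of amino on an aromatic carbon. Among the measured compounds shown here, two measured steps bear on this change: a 13-fold lower number from compound 1 to compound 2 (1.12 log units; beyond the scatter) and an 8.0-fold higher number from compound 2 to compound 3 (0.90 log units; beyond the scatter) both show the 3-((isopropylcarbonyl)amino)pyrrolidin-1-yl group giving a clearly lower number than either amino or cyclohexyl(methyl)amino. Compound 4 keeps the same five-membered ring but carries a bare amine on it instead of the isopropylcarbonyl amide. Because an 8.0-fold higher number from compound 2 to compound 3 (0.90 log units; beyond the scatter) is attributed to the whole amide-bearing ring and only part of it is retained here, a modest step down is expected, a 2.9-fold lower number from compound 3 to compound 4 (0.46 log units; beyond the scatter), short of the full gain seen with compound 2. Compound 4 is estimated at 250 nM in this assay, with a range from 60 nM to 1000 nM.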

Compound 4, half-maximal effective concentration: 200 nM
Estimate against measurement, compound 4: 1.3-fold (0.10 log units) above, and the stated range covers the measured number.
By their numbers in this assay, from the lowest: compound 2; then compound 4; then compounds 3 and 1 (each within the scatter of the next).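

In this assay, the ring and its acyl group can now be read apart: with a bare amine on the ring, 3-aminopyrrolidin-1-yl in place of amino on the aromatic carbon next to the ring nitrogen gives a 3.6-fold lower number from compound 3 to compound 4 (0.56 log units; beyond the scatter). The isopropylcarbonyl group on the amine nitrogen carries a separate step of its own, seen with hydrogen in its place as a 2.2-fold higher number from compound 2 to compound 4 (0.35 log units; beyond the scatter). Compounds 1 and 3 stay within the scatter of each other, whereas the ring-bearing compound 4 is clearly separated from the cyclohexyl(methyl)amino group, with a 6.0-fold lower number from compound 1 to compound 4 (0.78 log units; beyond the scatter).

Nothing shown accounts for either step. Still open, going by these compounds, is how the number responds to an acetyl group or a methanesulfonyl group on the ring amine, or to a piperidine ring in place of the pyrrolidine.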